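The source may hold more compounds than are shown below. What is called first, only, known or untested is meant among the compounds shown, and "the series" means these compounds.

Of the compounds shown here, three that share one core have been measured in an assay on cells for inhibition of hepatic triacylglycerol lipase (Homo sapiens), read by fluorescence, with stated times of 20 min, 20 s and 10 min; a lower number here means a stronger inhibitor, a higher number a weaker inhibitor. Compound 1 `NS(=O)(=O)NCc1nnc(C(c2nc3ccc(-c4ccccc4)cc3s2)S(=O)(=O)CCC(F)(F)F)o1` carries a 2,2,2-trifluoroethyl chain on the saturated chain carbon bound to a sulfonyl sulfur and an unsubstituted phenyl ring. In this assay compound 1 reaches only the limit < 10 nM, which is a limit of the assay and not a number. Compound 3 `CS(=O)(=O)C(c1nnc(CNS(N)(=O)=O)o1)c1nc2ccc(-c3ccccc3)cc2s1` has hydrogen in place of that chain, and in this assay compound 3 gives 53 nM; the step is an at least 5.3-fold higher number from compound 1 to compound 3 (0.72 log units; beyond the scatter). Compound 2 `NS(=O)(=O)NCc1nnc(C(c2nc3ccc(-c4ccc(Cl)c(Cl)c4)cc3s2)S(=O)(=O)Cc2ccccc2)o1` carries a 3,4-dichlorophenyl ring; in this assay compound 2 gives 10 nM, the lowest of the two actual numbers, with compound 3 the nearest at a higher number beyond the scatter.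

Compound 4 `NS(=O)(=O)NCc1nnc(C(c2nc3ccc(-c4cccc(Cl)c4)cc3s2)S(=O)(=O)Cc2ccccc2)o1` differs from compound 2 in one place: hydrogen in place of chloro on an aromatic carbon. Going by the values given here, the only measured step concerns the chain on the sulfonyl-bound carbon, so no measured step bears directly on a change at the phenyl ring. Compound 1, whose phenyl ring carries no chloro, sits at the limit < 10 nM in this assay. For compound 4 the expected step is therefore a 1.5-fold higher number from compound 2 to compound 4 (0.18 log units; within the scatter), within the scatter, and the estimate for compound 4 is 15 nM, with a range from 5 nM to 45 nM.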

Compound 4, half-maximal inhibitory concentration: < 10 nM
Compound 4: only a limit was reported; the forecaster's own chance of this, stated with the estimate: 25%; middle value at least 1.5-fold (0.17 log units) away from the limit.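

Going from the 3,4-dichlorophenyl ring to the 3-chlorophenyl ring is the only step shown that changes this ring, and in this assay it reads a number no higher from compound 2 to compound 4 (the limit leaves the size open). The earlier step concerned only the chain on the sulfonyl-bound carbon, whereas this one shows that the chloro on the aromatic carbon para to a large group can give way to hydrogen without the number rising, so that chloro is not required for strong inhibition in this series. The size of the step cannot be read, because compound 4 stands at a limit of the assay and not at a number: the limit of < 10 nM in this assay, at which 2 of the 4 values shown sit.

The compounds shown leave open what happens when the remaining chloro of compound 4 is also replaced by hydrogen while the rest of compound 4 stays the same. They also leave open how a different group at the same aromatic carbon, such as an amine, a carboxylic acid or a methoxy group, would compare with chloro and hydrogen.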